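Swapping the acetylphenyl arm of compound 1 for a dimethylphenyl

The compounds below may be only part of what the source reports. "The series", "measured", "known", "first", "only" and "open" are said of these compounds alone.

Measured so far:
compound 1 `COc1cc(-c2ccnc3cc(-c4ccc(C(C)=O)cc4)nn23)cc(OC)c1OC`: 5230 nM
compound 2 `Cc1ccc(-c2cc3nccc(-c4ccc(F)cc4)n3n2)cc1`: > 10000 nM
compound 3 `CCOC(=O)c1ccc(-c2cc3nccc(-c4cc(OC)c(OC)c(OC)c4)n3n2)cc1`: > 10000 nM

Going by the values given here, in a functional assay on MCF7 cells (Homo sapiens) for inhibition, read by CCK-8 assay, with a stated time of 48 h (on this read-out higher numbers stand for weaker inhibition and lower numbers for stronger inhibition), compound 1 gives 5230 nM, the only real number in the set. Compound 2 shows only the assay limit, > 10000 nM. Compound 3 likewise reaches only the limit, > 10000 nM. Among the compounds with values here, the single measured step, an at least 1.9-fold higher number from compound 1 to compound 3 (0.28 log units; that floor lies within the scatter), is a floor rather than a true size, so it says little about how far compound 3 actually falls; it is known only that (the limit of > 10000 nM in this assay, at which 2 of the 3 values shown sit).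

The new compound, compound 4 `COc1cc(-c2ccnc3cc(-c4ccc(C)c(C)c4)nn23)cc(OC)c1OC`, keeps the core of compound 1 and changes one arm: 3,4-dimethylphenyl in place of 4-acetylphenyl on an aromatic carbon. Within the data shown here, the closest point of comparison is compound 2, which carries a methylphenyl and sits at the limit in this assay, but its other arm also differs from compound 1, so no step can be drawn from it. With two of three values already at the limit and the step from compound 1 to compound 3 pointing the same way, a weaker result is expected for compound 4, most likely again at or near the limit.

The estimate for compound 4 is 12000 nM (range 4000 nM to 40000 nM), corresponding to an expected step of a 2.3-fold higher number from compound 1 to compound 4 (0.36 log units; beyond the scatter).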

Compound 4, half-maximal inhibitory concentration: 26 nM
The estimate for compound 4 lay 460-fold (2.66 log units) above the measured number; measured number below the stated range.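

In this assay, the arm on the aromatic carbon of the five-membered aromatic ring turns out to have a very strong hold on the read-out: with the rest of the molecule unchanged, 3,4-dimethylphenyl in place of 4-acetylphenyl gives a 200-fold lower number from compound 1 to compound 4 (2.30 log units; beyond the scatter). The earlier compounds shown here could not reveal this range, as only compound 1 carried a real number among them: the limit of > 10000 nM in this assay, at which 2 of the 4 values shown sit. The swap removes the carbonyl and brings in the methyl groups together, so this single step cannot say which of the two changes matters, or whether both do.

On these data alone, it remains open whether a single methyl group on this arm would be enough with the rest of compound 4 kept, and whether a phenyl ring carrying a methoxy group, a chlorine atom or an amine would be tolerated in the same place. Compound 2 has a methylphenyl arm but also differs in its second arm, so its value of > 10000 nM, which is a limit, cannot answer that.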